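This account rests on a few compounds, and the source may have more. Where it says the series, first, only, none or still open, it means among the compounds named here.

Values measured in an ADME assay on HeLa cells (Homo sapiens) for cytotoxicity, read by crystal violet staining, with a stated time of 72 h; on this read-out lower numbers stand for higher toxicity in this test and higher numbers for lower toxicity in this test:

- compound 1 `COC(=O)c1cc(CCCOc2c(C)cc(-c3noc(C(F)(F)F)n3)cc2C)on1` gives 35400 nM
- compound 2 `CCOC(=O)c1cc(CCCOc2ccc(-c3noc(C(F)(F)F)n3)cc2)on1` gives > 100000 nM, which is a limit
- compound 3 `CCOC(=O)c1cc(CCCOc2ccc(-c3noc(C(F)(F)F)n3)cc2C)on1` gives 35100 nM

Compound 2 has no numerical value in this assay, and its position is defined only by a limit: the limit of > 100000 nM in this assay, at which 1 of the 3 values shown sits. The next compound to be tested is compound 4 `CCOC(=O)c1cc(CCCOc2ccc(-c3noc(C(F)(F)F)n3)cc2OC)on1`. Its structural change is methoxy in place of hydrogen on an aromatic carbon.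

For the measured compounds named here, no methoxy step has been measured, so the closest guide is a methyl step on the same aromatic carbon. That step is an at least 2.8-fold lower number from compound 2 to compound 3 (0.45 log units; beyond the scatter), and it lies beyond the scatter. From the compounds shown here alone, its true size remains open, as it starts from a limit. The expectation for compound 4 therefore leans on compound 3, which carries methyl in place of that hydrogen and gives 35100 nM in this assay. A step of similar direction, toward a lower number, is expected, though one methyl step is thin support for a different group. The expected change is an at least 1.6-fold lower number from compound 2 to compound 4 (0.22 log units; that floor lies within the scatter) in this assay, and it may prove smaller than the methyl step. Compound 4 is estimated at 60000 nM, within an expected range from 25000 nM to 100000 nM.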

Compound 4, half-maximal cytotoxic concentration: > 100000 nM
Compound 4 was reported as a limit; the forecaster's own chance of this, stated with the estimate: 40%; at least 1.6-fold (0.22 log units) between middle value and limit.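

In this assay, the aromatic carbon that gave a lower number with methyl behaves differently with methoxy, and the exchange of one group for the other there is an at least 2.8-fold higher number from compound 3 to compound 4 (0.45 log units; beyond the scatter). The lower number of compound 3 therefore does not extend to every group larger than hydrogen at this carbon: among the compounds shown, it appears with methyl and not with methoxy, even though the two groups occupy the same place on the ring. The step from compound 2 to compound 4 cannot be read, and both compounds now stand at the same limit: the limit of > 100000 nM in this assay, at which 2 of the 4 values shown sit.

From the compounds shown here alone, the true numbers of compound 2 and compound 4 remain unknown, so whether methoxy differs from hydrogen at all on this read-out stays open. Also open, going by these compounds, is whether the lower number in this assay is particular to methyl or would also appear with an ethyl group, a chlorine atom or a hydroxyl group on the same aromatic carbon.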